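The source may hold more compounds than are shown below. What is called first, only, known or untested is meant among the compounds shown, and "the series" means these compounds.

Measured so far:
Compound 1, `COc1ccc(-c2cc3ccccc3nc2/C=C/C(=O)c2c(OC)cccc2OC)cc1`, gives 6630 nM in a functional assay on NCI-H460 cells (Homo sapiens) for antiproliferative activity, read by XTT assay, with a stated time of 72 h; a higher number here means a weaker inhibitor, a lower number a stronger inhibitor.
Compound 2, `COc1ccc(-c2cc3ccccc3nc2/C=C/C(=O)c2ccc(N)cc2)cc1`, gives 7400 nM in this assay.
Compound 3, `COc1ccc(-c2cc3ccccc3nc2/C=C/C(=O)c2ccc([N+](=O)[O-])cc2)cc1`, gives 6470 nM in this assay.

The three share one core and differ only in the aryl group attached to the carbonyl carbon. Compound 3 cannot be told apart from the other two: a 1.0-fold lower number from compound 1 to compound 3 (0.01 log units; within the scatter) and a 1.1-fold lower number from compound 2 to compound 3 (0.06 log units; within the scatter), both within the scatter. Compound 4, `COc1ccc(-c2cc3ccccc3nc2/C=C/C(=O)c2ccco2)cc1`, carries furan-2-yl in place of 4-nitrophenyl on a carbonyl carbon. Both measured exchanges at that carbonyl carbon bear on this change, and neither moved the number beyond the scatter, so no step beyond the scatter is expected here either. The expected step of a 1.0-fold higher number from compound 3 to compound 4 (0.00 log units; within the scatter) is within the scatter. Compound 4 is estimated at 6500 nM, with a likely range from 3000 nM to 14000 nM.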

Compound 4, half-maximal inhibitory concentration: 6430 nM
Compound 4: the middle estimate sits 1.0-fold (0.00 log units) above what was measured, within the range that was stated.
By their numbers in this assay, from the lowest: compounds 4, 3, 1 and 2 (each within the scatter of the next).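

Up to now every group on the carbonyl carbon was a six-membered aromatic ring of carbon only. Furan-2-yl, a five-membered aromatic ring with 1 hetero atom, shows that the ring itself can change in this assay and still give a 1.0-fold lower number from compound 3 to compound 4 (0.00 log units; within the scatter) and a 1.2-fold lower number from compound 2 to compound 4 (0.06 log units; within the scatter) and a 1.0-fold lower number from compound 1 to compound 4 (0.01 log units; within the scatter). Nothing measured here explains why this position tolerates such exchanges.

Open, going by these compounds, is whether a group with no aromatic ring on that carbonyl carbon, such as a methyl or a saturated amine, would also stay within the scatter.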